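The source may hold more compounds than are shown below. What is called first, only, known or untested is meant among the compounds shown, and "the series" means these compounds.

In an in vitro ADME assay on microsomes (Homo sapiens) for metabolic stability (a higher number here means that the compound lasts longer, a lower number that the compound disappears faster), compound 2 `CCCN(CC1CC1)c1nc(CC)c(-c2ccc(Cl)cc2Cl)nc1CC` at 0.2 h stands lowest of the two measured compounds, under compound 1 `CCc1nc(NC(CC)CC)c(F)nc1-c1ccc(Cl)cc1Cl` with its 1.22 h half-life. Compound 3 `CCc1nc(-c2ccc(Cl)cc2Cl)c(CC)nc1NC(CC)CC` follows from compound 2 through (pentan-3-yl)amino in place of (cyclopropylmethyl)(propyl)amino on an aromatic carbon on an aromatic carbon para to the 2,4-dichlorophenyl group. Among the compounds with values here, no measured step isolates this change, and the only guide is compound 1, which also carries (pentan-3-yl)amino and gives 1.22 h on a differently substituted core. The estimated step of a 3.5-fold higher number from compound 2 to compound 3 (0.54 log units; beyond the scatter) in this assay is an expected rise beyond the scatter. For compound 3 the expected half-life is 0.7 h within an estimated range of 0.3 h to 1.6 h for now.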

Compound 3, half-life: 0.283 h
Compound 3: middle estimate off by 2.5-fold (0.39 log units), on the high side; measured number below the stated range.
By their numbers in this assay, from the lowest: compounds 2 and 3 (each within the scatter of the next); then compound 1.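

Exchanging (cyclopropylmethyl)(propyl)amino for (pentan-3-yl)amino on this aromatic carbon gives a 1.4-fold higher number from compound 2 to compound 3 (0.15 log units; within the scatter) in this assay, so this read-out does not separate the two amino groups on the shared core. Within the data shown here, with (pentan-3-yl)amino held constant, ethyl in place of fluoro gives a 4.3-fold lower number from compound 1 to compound 3 (0.63 log units; beyond the scatter), the only step so far beyond the scatter. No supporting measurement explains either step. Going by these compounds, whether a morpholine at the amino position would change the half-life remains open. The same applies to a methoxy group or nitrile where ethyl replaced fluoro.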